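A few compounds are considered here, and "the series" means these few. Any claim that something is new, unique, unknown or untested is made for them only; others in the source may bear on it.

Measured so far in a functional assay on IGROV-1 cells (Homo sapiens) for inhibition, read by sulforhodamine B assay, with a stated time of 48 h, tested at 10 uM; a higher number here means more inhibition of growth at the concentration tested, a lower number less inhibition of growth: compound 2 `CC(=O)c1cccc(Nc2ccnc(SCC(=O)c3ccc(-c4ccccc4)cc3)n2)c1` gives 20%. Compound 3 `COc1ccc(C(=O)CSc2nccc(Nc3cccc(C(C)=O)c3)n2)cc1` gives 18%. Compound 1 `CC(=O)c1ccc(Nc2ccnc(SCC(=O)c3ccc(Br)cc3)n2)cc1` gives 12%.

On these numbers compound 2 stands highest, but its gaps to compound 3 and to compound 1 both lie within the scatter, so no order among the three can be read. The step from compound 2 to compound 4 `CC(=O)c1ccc(Nc2ccnc(SCC(=O)c3ccc(-c4ccccc4)cc3)n2)cc1` is 4-acetylphenyl in place of 3-acetylphenyl on a nitrogen on an aromatic ring. Within the data shown here, no measured pair differs in that place alone; the only one-place step on record, a number 2 percentage points lower from compound 2 to compound 3 (within the scatter), concerns another part of the molecule and stayed within the scatter. Compound 1, which carries the 4-acetylphenyl group, sits within the scatter of compound 3. Compound 4 is therefore expected to show a number 4 percentage points lower from compound 2 to compound 4 (within the scatter), a change not beyond the scatter, with an estimate of 16% and a range from 5% to 28%.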

Compound 4, percent growth inhibition at one concentration: 14%
The estimate for compound 4 lay 2 percentage points above the measured number; the range from low to high includes it.
By their numbers in this assay, from the lowest: compounds 1, 4, 3 and 2 (each within the scatter of the next).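

In this assay the change from 3-acetylphenyl to 4-acetylphenyl on the nitrogen now has a direct pair, which gives a number 6 percentage points lower from compound 2 to compound 4 (within the scatter) and so shows no effect that can be told from noise at this position. Phenyl in place of bromo on an aromatic carbon, read for the first time, gives a number 2 percentage points higher from compound 1 to compound 4 (within the scatter) and likewise separates nothing. No measurement at hand bears on either step.

As far as these compounds go, whether an amine or a carboxylic acid in place of the acetyl would move the number beyond the scatter remains open.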